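The source may report more compounds than this note shows. Statements on the series, on what has been measured and on what is new or still open speak of the compounds shown alone.

Of the compounds shown here, two of a shared core have been measured in an assay on CHO cells for displacement of a labelled ligand from Alpha-1B adrenergic receptor (Homo sapiens); on this read-out higher numbers stand for weaker inhibition and lower numbers for stronger inhibition. Compound 1 `COc1cccc(OC)c1OCCNCCOc1ccccc1OCc1ccc(C)cc1` gives 0.251 nM. Going by the values given here, compound 2 `COc1cccc(OC)c1OCCNCCOc1ccccc1OCc1cccc([N+](=O)[O-])c1` gives 0.794 nM, which is the higher of the two numbers, so compound 2 is the weaker inhibitor of the pair; the only measured step, a 3.2-fold higher number from compound 1 to compound 2 (0.50 log units; beyond the scatter), describes that gap.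

Compound 3 `COc1ccc(COc2ccccc2OCCNCCOc2c(OC)cccc2OC)cc1` is the next compound to be tested. The change from compound 2 is 4-methoxyphenyl in place of 3-nitrophenyl on a saturated chain carbon bound to an oxygen on an aromatic ring. That step undoes the nitro-bearing ring and brings in a ring with a methoxy group, which resembles the methyl-bearing ring of compound 1 more closely than the nitro-bearing ring of compound 2 does. Among the compounds with values here, the step from compound 1 to compound 2 is the one measured step that bears on this change, and it was modest. Compound 3 is therefore expected to move back toward the number of compound 1, with an estimated step of a 2.6-fold lower number from compound 2 to compound 3 (0.42 log units; beyond the scatter) in this assay. The estimate for compound 3 is 0.3 nM, with a range from 0.1 nM to 1 nM.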

Compound 3, inhibition constant: 0.398 nM
Compound 3: middle estimate off by 1.3-fold (0.12 log units), on the low side, within the range that was stated.
By their numbers in this assay, from the lowest: compounds 1, 3 and 2 (each within the scatter of the next, the first and the last beyond it).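

In this assay the change to 4-methoxyphenyl in place of 3-nitrophenyl on a saturated chain carbon gives a 2.0-fold lower number from compound 2 to compound 3 (0.30 log units; within the scatter) and so cannot be told apart from repeat-measurement scatter. Methoxy in place of methyl on an aromatic carbon gives a 1.6-fold higher number from compound 1 to compound 3 (0.20 log units; within the scatter) and is equally unreadable, so compound 3 separates from neither compound 1 nor compound 2, although those two differ from each other beyond the scatter. No supporting measurement is available to explain these numbers.

Because 3-nitrophenyl differs from 4-methylphenyl and 4-methoxyphenyl in both its group and that group's numbered place on the ring, the compounds shown do not separate those two changes. From the compounds shown here alone, how an amine or a carboxylic acid in place of methoxy on an aromatic carbon would read in this assay also remains open.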